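A Stereoisomer of a Compound Stuck at the Assay Limit

The compounds below may be only part of what the source reports. "The series", "measured", "known", "first", "only" and "open" are said of these compounds alone.

In a functional assay on RAW264.7 cells (Mus musculus) for inhibition, read by Griess assay, with stated times of 2 h and 20 h (on this read-out lower numbers stand for stronger inhibition and higher numbers for weaker inhibition), compound 1 (`COC1=C(C)C(=O)C2=C(O[C@]3(CC[C@@H]4C[C@@H]3C4(C)C)C[C@@H]2C(C)C)C1(C)C`) gives a numerical value (3700 nM) for inhibition. Compound 2 (`COC1=C(C)C(=O)C2=C(O[C@@]3(C=C4[C@H](C(C)C)CC[C@@H](C)[C@H]4CC3)C[C@H]2C(C)C)C1(C)C`) gives only a limit (> 50000 nM) in this assay and no number. Compound 3 (`COC1=C(C)C(=O)C2=C(O[C@]3(C=C4[C@H](C(C)C)CC[C@@H](C)[C@H]4CC3)C[C@@H]2C(C)C)C1(C)C`) is the next compound to be tested. It keeps the atoms and bonds of compound 2 and differs only in configuration as drawn (the two compounds have the same atoms and bonds and differ only in configuration as drawn: 2 of 5 stereo elements differ; a stereocentre at a saturated ring carbon is drawn R in compound 2 and S in compound 3; a stereocentre at a saturated ring carbon is drawn S in compound 2 and R in compound 3). One stereocentre at a saturated ring carbon is drawn R in compound 2 and S in compound 3, and another is drawn S in compound 2 and R in compound 3. Within the data shown here, no measured pair in this set shows what such a change does, so the size of the step remains uncertain. Compound 1 (3700 nM) shows that a numerical reading is possible in this assay for a compound sharing part of this structure. A moderate move towards stronger inhibition is therefore expected (an at least 2.2-fold lower number from compound 2 to compound 3 (0.35 log units; beyond the scatter)) as the estimated step. For compound 3 the estimate is (22000 nM), expected to fall within 5000 nM to 50000 nM in most repeat measurements, although another reading at the limit would be no surprise.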

Compound 3, half-maximal inhibitory concentration: > 50000 nM
Compound 3 gave a limit, no number; the forecaster's own chance of this, stated with the estimate: 45%; at least 2.2-fold (0.35 log units) between middle value and limit.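

In this assay compound 3 gives > 50000 nM, which is a limit and not a number. Among these compounds, no step between compound 2 and compound 3 can be read, because both rest on the same limit: the limit of > 50000 nM in this assay, at which 2 of the 3 values shown sit. The compounds shown leave open whether configuration alone changes inhibition here, and by how much: the fact that compounds 2 and 3 differ only in the configuration as drawn.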